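A Third Methoxy on the Lactone Series

A few compounds are considered here, and "the series" means these few. Any claim that something is new, unique, unknown or untested is made for them only; others in the source may bear on it.

Of the compounds shown here, two have been measured so far in a functional assay on NCI/ADR cells (Homo sapiens) for inhibition, read by sulforhodamine B assay, with a stated time of 48 h; a lower number here means a stronger inhibitor of growth, a higher number a weaker inhibitor of growth. Compound 1 `COc1cc(/C=C/C2CC(=O)C=CO2)cc(OC)c1OC` gives 223 uM, while compound 2 `COc1cc(/C=C/C2CC=CC(=O)O2)cc(OC)c1` gives 8.9 uM, the lowest of the two numbers and a gap beyond the scatter. Compound 3 `COc1cc(/C=C/C2CC=CC(=O)O2)cc(OC)c1OC` differs from compound 2 by a single change: methoxy in place of hydrogen on an aromatic carbon. Since compound 1 differs from compound 2 in more than one place, its weaker result cannot be traced to the methoxy alone. A mild loss is expected, with the step from compound 2 to compound 3 estimated as a 2.0-fold higher number from compound 2 to compound 3 (0.31 log units; beyond the scatter). Compound 3 is therefore expected to give about 18 uM, within a range of 5 uM to 65 uM.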

Compound 3, concentration for growth inhibition (reported as GI): 35.1 uM
Beside the measured number, compound 3's estimate is 2.0-fold (0.29 log units) below it; measured number inside the range.
By their numbers in this assay, from the lowest: compound 2; then compound 3; then compound 1.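

In this assay, placing a methoxy on the aromatic carbon ortho to two methoxy groups gives a 3.9-fold higher number from compound 2 to compound 3 (0.60 log units; beyond the scatter) and so weakens growth inhibition at this position. With all three methoxy groups kept, exchanging one six-membered ring group for the other gives a 6.4-fold lower number from compound 1 to compound 3 (0.80 log units; beyond the scatter) and shows that the ring group matters separately from the methoxy. Nothing measured here explains either step.

At this carbon, only hydrogen and methoxy can be compared. Going by these compounds, how a hydroxyl, a chlorine or a longer ethoxy chain there would behave remains open.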